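Methylsulfanyl to Iodo: What to Expect of Compound 3

The compounds below may be only part of what the source reports. "The series", "measured", "known", "first", "only" and "open" are said of these compounds alone.

Compound 1 `CCCc1cc(N)c2cc(NC(=O)/C=C/c3ccc(C(C)C)cc3)ccc2n1`: 2.9 nM
Compound 2 `CCCc1cc(N)c2cc(NC(=O)/C=C/c3ccc(SC)cc3)ccc2n1`: 9 nM

Both numbers come from an assay on isolated protein for displacement of a labelled ligand from melanin-concentrating hormone receptor 1 (Homo sapiens); on this read-out lower numbers stand for stronger inhibition and higher numbers for weaker inhibition. Compound 2 stands at the higher of the two, separated from compound 1 by a single measured step, a 3.1-fold higher number from compound 1 to compound 2 (0.49 log units; beyond the scatter). Compound 3 `CCCc1cc(N)c2cc(NC(=O)/C=C/c3ccc(I)cc3)ccc2n1` has not yet been measured; it differs from compound 2 only by iodo in place of methylsulfanyl on an aromatic carbon. Among the compounds with values here, no measured step carries this exact exchange. Within the data shown here, the one step that bears on the same aromatic carbon, a 3.1-fold higher number from compound 1 to compound 2 (0.49 log units; beyond the scatter), shows that swapping one group for another at this place moves the number by a modest amount only. Iodo is a single substituent at the same place, so the step expected is a 1.3-fold lower number from compound 2 to compound 3 (0.11 log units; within the scatter), a shift that would sit within the usual scatter. In this assay compound 3 is therefore expected to give about 7 nM, with a range from 2.5 nM to 20 nM.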

Compound 3, half-maximal inhibitory concentration: 2.3 nM
Beside the measured number, compound 3's estimate is 3.0-fold (0.48 log units) above it; measured number outside the range, below it.
By their numbers in this assay, from the lowest: compounds 3 and 1 (each within the scatter of the next); then compound 2.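

In this assay, iodo in place of methylsulfanyl gives a 3.9-fold lower number from compound 2 to compound 3 (0.59 log units; beyond the scatter), so methylsulfanyl is now below two other groups at this place on the ring, not just isopropyl. Iodo in place of isopropyl gives a 1.3-fold lower number from compound 1 to compound 3 (0.10 log units; within the scatter), which means that these two different groups, one a single iodine atom and the other a branched carbon group, cannot be told apart here. Of the three groups seen at this place, methylsulfanyl alone stands apart, and nothing available explains why.

The compounds shown leave open how this place would respond to a quite different group, such as an amine, a carboxylic acid or a longer alkyl chain. As far as these compounds go, all three compounds share one core, so whether these exchanges would give similar steps on any other core also remains open.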